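The compounds below may be only part of what the source reports. "The series", "measured", "known", "first", "only" and "open" are said of these compounds alone.

The study concerns two amino-substituted tetrahydrofuran cores carrying a long alkylamine chain. Going by the values given here, compound 1, `CCCCCCCCCCCNC[C@@H]1OC[C@H](N)[C@H]1O`, is the only member of the set with a measured number: in a functional assay on A549 cells (Homo sapiens) for antiproliferative activity, read by MTT assay, with a stated time of 72 h (a lower number here means a stronger inhibitor, a higher number a weaker inhibitor), compound 1 gives 9650 nM. Among the compounds with values here, compound 2, `CCCCCCCNC[C@@H]1OC[C@H](N)[C@@H]1O`, is reported only as a limit of the assay, at > 128000 nM in this assay, so the pair offers no step between measured compounds (the limit of > 128000 nM in this assay, at which 1 of the 2 values shown sits).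

Compound 3, `CCCCCCCCCCCCCCNC[C@@H]1OC[C@H](N)[C@H]1O`, is not yet measured. It differs from compound 1 by propyl in place of hydrogen on a saturated chain carbon, ten or more bonds along the chain from an amine nitrogen, a lengthening of the chain at its far end. Within the data shown here, with no measured step between compounds of like kind to lean on, the change is expected to move this assay only modestly, if at all, and toward stronger inhibition rather than weaker. Compound 3 is therefore expected to give about 5000 nM, within roughly 1500 nM to 16000 nM, a step of a 1.9-fold lower number from compound 1 to compound 3 (0.29 log units; within the scatter) that may well stay inside the usual scatter.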

Compound 3, half-maximal inhibitory concentration: 20000 nM
Compound 3: middle estimate off by 4.0-fold (0.60 log units), on the low side; measured number outside the range, above it.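

Lengthening the chain does not strengthen inhibition at this position: in this assay, propyl in place of hydrogen on a saturated chain carbon gives a 2.1-fold higher number from compound 1 to compound 3 (0.32 log units; beyond the scatter). This first measured step shows that the far end of the chain is not indifferent to added carbon, although the change is modest. Compound 2 is reported only as a limit and differs from compound 1 in more than one place, so it adds no second step along the chain: the limit of > 128000 nM in this assay, at which 1 of the 3 values shown sits.

One step cannot show whether a shorter chain than that of compound 1 would give a stronger or a weaker number. It also leaves open how a hydroxyl, an amine or a carboxylic acid at the far end of the chain would compare.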